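The source may hold more compounds than are shown below. What is called first, only, known or untested is meant among the compounds shown, and "the series" means these compounds.

Measured compounds:
compound 1 `Nc1ccccc1NC(=O)c1ccc(CSc2ccc(Br)cc2)cc1` — in a functional assay on HeLa cells (Homo sapiens) for inhibition, read by CCK-8 assay, with a stated time of 72 h, tested at 2 uM (a lower number here means less inhibition of growth, a higher number more inhibition of growth at the concentration tested), compound 1 gives 18.8%
compound 2 `Nc1ccccc1NC(=O)/C=C/c1ccc(CSc2ccc(Cl)cc2)cc1` — compound 2 gives 1.94%
compound 3 `Nc1ccccc1NC(=O)c1ccc(CSc2ccc(C(F)(F)F)cn2)cc1` — compound 3 gives 11.5%

Compound 2 holds the smallest of the three numbers. Its gap to compound 3 lies within the scatter of repeated measurements, so the two cannot be separated; its gap to compound 1 lies beyond the scatter, so compound 1 shows more inhibition of growth than compound 2.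

Compound 4 `Nc1ccccc1NC(=O)/C=C/c1ccc(CSc2cccc3ccccc23)cc1` is not yet measured. It differs from compound 2 in one place: naphthalen-1-yl in place of 4-chlorophenyl on a sulfur. For the measured compounds named here, no measured pair in this set isolates that change, so nothing here tells how large a step such an exchange on the sulfur produces in this assay. Given that, the step is expected to be small, most likely within the scatter, with the direction open; a modest rise is as plausible as no change. Compound 4 is therefore estimated at 8%, with a range from 0% to 25%. This estimate implies a step of a number 6.1 percentage points higher from compound 2 to compound 4 (within the scatter), expected to stay inside the usual scatter.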

Compound 4, percent growth inhibition at one concentration: 20.6%
The estimate for compound 4 lay 12.6 percentage points below the measured number; the measured number falls inside the stated range.
By their numbers in this assay, from the lowest: compounds 2, 3, 1 and 4 (each within the scatter of the next, the first and the last beyond it).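

The group on the sulfur is not a silent position in this assay: naphthalen-1-yl in place of 4-chlorophenyl gives a number 18.7 percentage points higher from compound 2 to compound 4 (beyond the scatter), the first single-place step readable in this series. The exchange both adds a second six-membered aromatic ring of carbon only and removes the chlorine, so the step cannot be assigned to either alteration alone. No data shown bear on the cause of this step.

Still open, as far as these compounds go, is whether the second ring itself carries the step, which a phenyl without chlorine or a naphthalen-2-yl on the sulfur would help to separate. Also open, from the compounds shown here alone, are the same exchange on the core of compound 1 and the outcome with a saturated group on the sulfur, such as a cyclohexyl ring or a longer alkyl chain.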